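A few compounds are considered here, and "the series" means these few. Any claim that something is new, unique, unknown or untested is made for them only; others in the source may bear on it.

Measured in a functional assay on B16-F10 cells (Mus musculus) for antiproliferative activity, read by CCK-8 assay, with a stated time of 48 h; a higher number here means a weaker inhibitor, a lower number a stronger inhibitor:
Compound 1 `COc1ccc(/C=C\c2cc(OC)c(OC)c(OC)c2)cc1OCc1ccc(CNC(C)(C)C(=O)O)cc1`: > 10000 nM, a limit of the assay
Compound 2 `COc1ccc(/C=C\c2cc(OC)c(OC)c(OC)c2)cc1OCc1ccc(CN2CC[C@H](C(=O)O)C2)cc1`: 7000 nM
Compound 3 `COc1ccc(/C=C\c2cc(OC)c(OC)c(OC)c2)cc1OCc1ccc(CO)cc1`: 6600 nM

Compound 3 stands at 6600 nM, and compound 2 stands at 7000 nM. These two numbers lie within the scatter of each other. Compound 4 `COc1ccc(/C=C\c2cc(OC)c(OC)c(OC)c2)cc1OCc1ccc(CNCCNC(C)=O)cc1` keeps the shared core and differs from compound 3 in one place: (2-acetamidoethyl)amino in place of hydroxy on a saturated chain carbon bound to an aromatic carbon. Here (2-acetamidoethyl)amino replaces hydroxy on a saturated chain carbon bound to an aromatic carbon.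

Three measured steps at this same carbon bear on the change: a 1.1-fold lower number from compound 2 to compound 3 (0.03 log units; within the scatter), an at least 1.4-fold lower number from compound 1 to compound 2 (0.15 log units; that floor lies within the scatter) and an at least 1.5-fold lower number from compound 1 to compound 3 (0.18 log units; that floor lies within the scatter). The last two are only floors, and none of the three goes beyond the scatter. The entering group matches none of those already measured at this carbon, so they are only a loose guide. In this assay, no step beyond the scatter is therefore expected in either direction. The expected step is a 1.7-fold lower number from compound 3 to compound 4 (0.22 log units; within the scatter). For compound 4 the estimate is 4000 nM, with an expected range of 1000 nM to 12000 nM.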

Compound 4, half-maximal inhibitory concentration: 2500 nM
Compound 4: middle estimate off by 1.6-fold (0.20 log units), on the high side; the range from low to high includes it.
By their numbers in this assay, from the lowest: compound 4; then compounds 3 and 2 (each within the scatter of the next). At a limit, above all of these: compound 1.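

In this assay, this saturated chain carbon bound to an aromatic carbon gives its first steps beyond the scatter once (2-acetamidoethyl)amino enters: a 2.6-fold lower number from compound 3 to compound 4 (0.42 log units; beyond the scatter) and a 2.8-fold lower number from compound 2 to compound 4 (0.45 log units; beyond the scatter). The position therefore responds to the group it carries, and on the amine nitrogen 2-acetamidoethyl also compares favourably with 1-carboxy-1-methylethyl, with an at least 4.0-fold lower number from compound 1 to compound 4 (0.60 log units; beyond the scatter). That last step is only a floor, because compound 1 stands at a limit of the assay: the limit of > 10000 nM in this assay, at which 1 of the 4 values shown sits.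

The compounds shown do not tell whether the step belongs to the amine nitrogen, to the acetamide or to the two together. A plain ethylamine, a longer chain between the two nitrogens or a terminal primary amine in place of the acetamide would bear on that question.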